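The compounds below may be only part of what the source reports. "The series", "measured", "known", "first", "only" and "open" are said of these compounds alone.

The study here looks at two close analogues of one shared core, a urea linked to an aromatic core that in turn carries a second aromatic amine. Compound 1 `COc1ccc(F)cc1Nc1cc(NC(=O)Nc2c(Cl)cccc2Cl)ncn1` and compound 2 `COc1cc(NC(=O)Nc2cc(Nc3cc(F)ccc3OC)ncn2)cc(OC)c1` differ only on the amide-type nitrogen, where compound 2 carries 3,5-dimethoxyphenyl in place of 2,6-dichlorophenyl. Among the compounds with values here, in a functional assay on NCI-H226 cells (Homo sapiens) for inhibition, read by MTT assay, with a stated time of 48 h, tested at 10 uM (on this read-out lower numbers stand for less inhibition and higher numbers for more inhibition at the one concentration tested (going by the name of the read-out)), compound 1 gives 31.3%, and compound 2 gives 37.7%; the step of a number 6.4 percentage points higher from compound 1 to compound 2 (within the scatter), so the two compounds cannot be told apart on this read-out, and compound 2 stands level with the only other measured compound.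

Compound 3 `COc1cc(NC(=O)Nc2cc(Nc3ccc(OC)c(C)c3)ncn2)cc(OC)c1` keeps the 3,5-dimethoxyphenyl of compound 2 and changes the other end instead: 4-methoxy-3-methylphenyl in place of 5-fluoro-2-methoxyphenyl on a nitrogen on an aromatic ring. Within the data shown here, no measured step touches this nitrogen; the one step known concerns the amide-type nitrogen and was itself within the scatter. With nothing pointing in either direction, the expectation for compound 3 is a step of a number 0.7 percentage points lower from compound 2 to compound 3 (within the scatter), that is no change beyond the scatter, and compound 3 is estimated at 37%, with a range from 20% to 55%.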

Compound 3, a percentage reported as inhibition, at one concentration (the size of the read-out at that concentration, not a potency): 39.7%
Compound 3: middle estimate off by 2.7 percentage points, on the low side, within the range that was stated.
By their numbers in this assay, from the lowest: compounds 1, 2 and 3 (each within the scatter of the next).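

In this assay, putting 4-methoxy-3-methylphenyl in place of 5-fluoro-2-methoxyphenyl on the nitrogen on an aromatic ring gives a number 2 percentage points higher from compound 2 to compound 3 (within the scatter), so this end of the molecule now has a measured step of its own, and that step cannot be told apart from no change. Each end of the molecule has now been changed once among these three compounds, and neither replacement moved the number beyond the scatter. Nothing further is available here to help interpret this result.

Still open, on these data alone, is whether an amine such as morpholine, a carboxylic acid or a longer alkyl chain in place of the aromatic ring on this nitrogen would move the number beyond the scatter. A reading at one concentration also leaves open how the potencies of these compounds compare.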